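Replacing piperazine with diethylamine on a chromone side chain

This account rests on a few compounds, and the source may have more. Where it says the series, first, only, none or still open, it means among the compounds named here.

Among the measured compounds shown here, compound 1 `COc1c(OCCCN2CCNCC2)cc(O)c2c(=O)cc(-c3ccccc3)oc12` is the only member of this set with a number behind it: in a functional assay on A549 cells (Homo sapiens) for cytotoxicity, read by MTT assay, with a stated time of 48 h (a higher number here means a weaker inhibitor, a lower number a stronger inhibitor), compound 1 gives 10100 nM. Compound 2 `CCCCNCCCCOc1c(O)cc(O)c2c(=O)cc(-c3ccccc3)oc12` and compound 3 `CC(C)NCCOc1c(O)cc(O)c2c(=O)cc(-c3ccccc3)oc12` belong to the same study, but no result was reported for them: in this assay compound 2 gives "not determined" (no result reported), and in this assay compound 3 gives "not determined" (no result reported), so compound 1 stands alone on the numbers shown. Compound 4 `CCN(CC)CCCOc1cc(O)c2c(=O)cc(-c3ccccc3)oc2c1OC` is derived from compound 1 by a single change: diethylamino in place of piperazin-1-yl on a saturated chain carbon, three bonds along the chain from an oxygen on an aromatic ring. For the measured compounds named here, no step between measured compounds is available, so nothing in these data shows how far such an exchange moves the read-out. The writer expects the step of a 1.1-fold lower number from compound 1 to compound 4 (0.05 log units; within the scatter) to remain within the usual scatter, with no clear direction. Compound 4 is therefore estimated at 9000 nM in this assay, within a range from 4000 nM to 25000 nM.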

Compound 4, half-maximal inhibitory concentration: 1830 nM
Compound 4: the middle estimate sits 4.9-fold (0.69 log units) above what was measured, outside the stated range (below it).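

In this assay, among the compounds shown here, diethylamino in place of piperazin-1-yl at this place on the chain gives a 5.5-fold lower number from compound 1 to compound 4 (0.74 log units; beyond the scatter) as the only readable step in the set. It shows that the read-out responds to the group at the end of this chain, and that here diethylamino is the stronger of the two. Nothing given here accounts for this difference.

From the compounds shown here alone, whether morpholin-4-yl or pyrrolidin-1-yl in the same place would match diethylamino remains open. So does whether diethylamino on a longer chain would hold the same read-out.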